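Trimethoxyphenyl triazole phthalimides: removing the aryl ketone arm

The source may report more compounds than this note shows. Statements on the series, on what has been measured and on what is new or still open speak of the compounds shown alone.

Compound 1 `Cc1ccc(C(=O)CSc2nnc(C)n2N2C(=O)c3ccccc3C2=O)cc1`, compound 2 `CSc1nnc(C)n1N1C(=O)c2ccccc2C1=O` and compound 3 `COc1cc(-c2nnc(SCC(=O)c3ccc(C)cc3)n2N2C(=O)c3ccccc3C2=O)cc(OC)c1OC` share a core; compound 4 `COc1cc(-c2nnc(SC)n2N2C(=O)c3ccccc3C2=O)cc(OC)c1OC` is not yet measured. In a functional assay on A549 cells (Homo sapiens) for cytotoxicity, read by MTT assay, with a stated time of 48 h (on this read-out lower numbers stand for stronger inhibition and higher numbers for weaker inhibition), compound 1 gives > 200000 nM, which is a limit of the assay and not a number. Compound 2 gives > 200000 nM in this assay, again a limit rather than a number. Among the compounds with values here, compound 3 gives 6760 nM, the only plain number in the set.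

The change from compound 1 to compound 2 is hydrogen in place of (4-methylphenyl)carbonyl on a saturated chain carbon bound to a sulfur; its step is a step that the two limits leave unreadable from compound 1 to compound 2, since both values sit at the limit (the limit of > 200000 nM in this assay, at which 2 of the 3 values shown sit). The cores of compound 1 and compound 3 differ by 3,4,5-trimethoxyphenyl in place of methyl on an aromatic carbon, and that step is an at least 29-fold lower number from compound 1 to compound 3 (1.47 log units; beyond the scatter). The change from compound 3 to compound 4 is hydrogen in place of (4-methylphenyl)carbonyl on a saturated chain carbon bound to a sulfur, the same change as from compound 1 to compound 2, at the same place.

What the earlier step of this change would have shown is hidden by the two limits. Within the data shown here, the size expected here rests only on compound 3 having the single readable value 6760 nM and on compound 2, which carries the same methylsulfanyl end. Compound 2 sits at the limit > 200000 nM. For compound 4 the expected step is a 4.4-fold higher number from compound 3 to compound 4 (0.65 log units; beyond the scatter), towards weaker inhibition, with wide uncertainty. Compound 4 is therefore estimated at 30000 nM, between 8000 nM and 200000 nM, with a real chance that only a limit is reported.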

Compound 4, half-maximal inhibitory concentration: > 200000 nM
Compound 4 was reported as a limit; the forecaster's own chance of this, stated with the estimate: 35%; middle value at least 6.6-fold (0.82 log units) from the limit.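

In this assay, hydrogen in place of (4-methylphenyl)carbonyl on a saturated chain carbon bound to a sulfur gives an at least 29-fold higher number from compound 3 to compound 4 (1.47 log units; beyond the scatter), so on the core carrying 3,4,5-trimethoxyphenyl, the readable value of compound 3 is lost once this arm is cut back to methylsulfanyl. Compound 4 gives > 200000 nM, which is a limit of the assay and not a number. The same change on the core of compound 1, from compound 1 to compound 2, cannot be read, so these compounds show a large step on one core but do not show whether its size carries over to the other: the limit of > 200000 nM in this assay, at which 3 of the 4 values shown sit.

The compounds shown compare only two ends on the sulfur, (((4-methylphenyl)carbonyl)methyl)sulfanyl and methylsulfanyl, which leaves open whether the carbonyl, the 4-methylphenyl ring or the two together are needed for a readable value on the 3,4,5-trimethoxyphenyl core. Also open, from the compounds shown here alone, is how this core would respond to other ends on the sulfur, such as a plain benzyl group, a longer chain or a chain ending in a carboxylic acid or an amine.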